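From Methoxy to Fluorine in a Series Below Detection

The source may report more compounds than this note shows. Statements on the series, on what has been measured and on what is new or still open speak of the compounds shown alone.

Compound 1 `O=C(/C=C/c1ccccc1)NCCCCNc1ccnc2cc(Cl)ccc12`, compound 2 `CC(C)c1ccc(/C=C/C(=O)NCCCCNc2ccnc3cc(Cl)ccc23)cc1` and compound 3 `COc1ccc(/C=C/C(=O)NCCCCNc2ccnc3cc(Cl)ccc23)cc1` share one core and differ only in the group carried on the aromatic ring at the far end of the chain. In an ADME assay on HFF-1 cells (Homo sapiens) for antiproliferative activity, read by sulforhodamine B assay, with a stated time of 2 days (on this read-out higher numbers stand for weaker inhibition of growth and lower numbers for stronger inhibition of growth), compound 1 gives > 100000 nM, which is a limit of the assay rather than a number. Compound 2 likewise gives > 100000 nM, also a limit. Compound 3 gives > 100000 nM, again a limit, so its place on the scale is known only as a bound. The steps a step that the two limits leave unreadable from compound 1 to compound 2, a step that the two limits leave unreadable from compound 1 to compound 3 and a step that the two limits leave unreadable from compound 2 to compound 3 therefore cannot be read in size or direction. What the three values show is the limit of > 100000 nM in this assay, at which 3 of the 3 values shown sit. Compound 4 `O=C(/C=C/c1cccc(F)c1)NCCCCNc1ccnc2cc(Cl)ccc12` differs from compound 3 in that (3-fluorophenyl in place of 4-methoxyphenyl on a double-bonded chain carbon bound to a double-bonded chain carbon). Going by the values given here, no measured step bears on this change with a readable size. Compound 4 is expected to sit at the same limit, a step that the limit leaves unreadable from compound 3 to compound 4, that is, nothing beyond the scatter. The estimate for compound 4 is 200000 nM, between 70000 nM and 600000 nM.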

Compound 4, concentration for 50% growth inhibition: > 100000 nM
Compound 4: a limit, no number (the forecaster's own chance of this, stated with the estimate: 85%); the middle value lies beyond the limit too.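

In this assay, going by these compounds alone, compound 4 gives > 100000 nM, which is a limit and not a number, so no step among compound 1, compound 2, compound 3 and compound 4 can be read. The compounds shown leave open whether these groups on the aromatic ring differ at all in their effect on growth, because all four values rest at one bound: the limit of > 100000 nM in this assay, at which 4 of the 4 values shown sit.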